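Hydrazone aryl variation: hydroxy dimethyl phenyl replaces dichlorophenyl

The source may hold more compounds than are shown below. What is called first, only, known or untested is meant among the compounds shown, and "the series" means these compounds.

Compound 1 `CN(C)CCn1cnnc1-c1cc(Oc2ccc(NC(=O)N/N=C/c3cccc(Cl)c3Cl)cc2F)ccn1` carries a 2,3-dichlorophenyl on the carbon with a double bond to nitrogen. In an ADME assay on WI-38 cells (Homo sapiens) for cytotoxicity, read by MTT assay, with a stated time of 72 h (on this read-out higher numbers stand for weaker inhibition and lower numbers for stronger inhibition), compound 1 gives 6130 nM, the highest of the two numbers recorded; the nearest is compound 3 `CN(C)CCn1cnnc1-c1cc(Oc2ccc(NC(=O)N/N=C/c3c(O)ccc4ccccc34)cc2F)ccn1`, which in this assay gives 3250 nM. For the measured compounds named here, the only single-point step among the measured compounds is a 1.9-fold lower number from compound 1 to compound 3 (0.28 log units; within the scatter), so exchanging the dichlorophenyl for a hydroxy-bearing aryl did not move the number beyond the scatter. Compound 2 `CN(C)CCn1cnnc1-c1cc(Oc2ccc(NC(=O)N/N=C/c3cc(Br)c(O)c(Br)c3)cc2F)ccn1`, with a second hydroxy-bearing aryl, has no result in this assay ("not determined" (no result reported)), so it adds nothing to the comparison.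

Compound 4 `Cc1cc(/C=N/NC(=O)Nc2ccc(Oc3ccnc(-c4nncn4CCN(C)C)c3)c(F)c2)cc(C)c1O` is the next point. The change from compound 1 is 4-hydroxy-3,5-dimethylphenyl in place of 2,3-dichlorophenyl on a carbon with a double bond to nitrogen. The step from compound 1 to compound 3 bears on it directly, since both bring a hydroxy group onto the aryl in the same place, and that step stayed within the scatter. A step within the scatter, if anything toward a lower number, is therefore expected here, and a 1.4-fold lower number from compound 1 to compound 4 (0.13 log units; within the scatter) is the estimated size. For compound 4 the expected value in this assay is 4500 nM, with a range from 1500 nM to 13000 nM.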

Compound 4, half-maximal inhibitory concentration: 3610 nM
Beside the measured number, compound 4's estimate is 1.2-fold (0.10 log units) above it; low and high end bracket the measured number.
By their numbers in this assay, from the lowest: compounds 3, 4 and 1 (each within the scatter of the next).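

In this assay, replacing 2,3-dichlorophenyl with 4-hydroxy-3,5-dimethylphenyl on the carbon with a double bond to nitrogen gives a 1.7-fold lower number from compound 1 to compound 4 (0.23 log units; within the scatter), so this second hydroxy-bearing aryl, which has no chlorine and carries two methyl groups, also stays level with compound 1. For the compounds shown here, the comparison of the two hydroxy-bearing aryl groups gives a 1.1-fold higher number from compound 3 to compound 4 (0.05 log units; within the scatter), which adds what the earlier compounds could not show: 4-hydroxy-3,5-dimethylphenyl and 2-hydroxynaphthalen-1-yl cannot be told apart on this read-out, so all three measured aryl groups now sit within the scatter of one another at this position. No measured information is available to account for this flat picture.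

From the compounds shown here alone, compound 2 has no number, so any step involving it cannot be read, and the 3,5-dibromo-4-hydroxyphenyl case stays open. All the compounds shown carry an aryl group at this position, leaving open whether the number would hold with an aryl bearing an amine or a carboxylic acid, or with a longer alkyl chain in place of the aryl.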